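This account rests on a few compounds, and the source may have more. Where it says the series, first, only, none or still open, it means among the compounds named here.

Working notes on the series in a functional assay on HepG2 cells (Homo sapiens) for cytotoxicity, read by MTT assay, with a stated time of 72 h; a lower number here means a stronger inhibitor, a higher number a weaker inhibitor. Compound 1 `CN1[C@@H]2c3[nH]c4ccccc4c3C[C@H]1[C@H](C#N)N1[C@@H](CNC(=O)c3ccc(Cl)cc3)c3[nH]c4ccccc4c3C[C@@H]21` gives 350 nM and compound 2 `COc1ccc(C(=O)NC[C@H]2c3[nH]c4ccccc4c3C[C@H]3[C@H]4c5[nH]c6ccccc6c5C[C@@H]([C@H](C#N)N23)N4C)cc1` gives 310 nM, with a 1.1-fold lower number from compound 1 to compound 2 (0.05 log units; within the scatter). Compound 3 `CN1[C@@H]2c3[nH]c4ccccc4c3C[C@H]1[C@H](C#N)N1[C@@H](CNC(=O)c3ccc4ccccc4c3)c3[nH]c4ccccc4c3C[C@@H]21` gives 1210 nM, the highest of the three numbers: a 3.5-fold higher number from compound 1 to compound 3 (0.54 log units; beyond the scatter) and a 3.9-fold higher number from compound 2 to compound 3 (0.59 log units; beyond the scatter). Compound 4 `CN1[C@@H]2c3[nH]c4ccccc4c3C[C@H]1[C@H](C#N)N1[C@@H](CNC(=O)c3ccc4ccccc4n3)c3[nH]c4ccccc4c3C[C@@H]21` differs from compound 3 by quinolin-2-yl in place of naphthalen-2-yl on a carbonyl carbon. Among the measured compounds shown here, no measured step exchanges one bicyclic aryl for another, so none bears directly; the closest comparison is the ring substitution from compound 1 to compound 2, which stayed within the scatter, whereas the two steps into compound 3 were modest. For compound 4 the expected step is therefore a 1.2-fold lower number from compound 3 to compound 4 (0.08 log units; within the scatter), likely not beyond the scatter. Compound 4 is estimated at 1000 nM, range 400 nM to 3000 nM.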

Compound 4, half-maximal inhibitory concentration: 110 nM
Compound 4: the middle estimate sits 9.1-fold (0.96 log units) above what was measured; measured number below the stated range.
By their numbers in this assay, from the lowest: compound 4; then compounds 2 and 1 (each within the scatter of the next); then compound 3.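

At the carbonyl carbon, one ring nitrogen is the only difference between the two bicyclic groups, yet quinolin-2-yl in place of naphthalen-2-yl gives an 11-fold lower number from compound 3 to compound 4 (1.04 log units; beyond the scatter) in this assay and so shows that this position is sensitive to more than ring size. A bicyclic group is also not always the weaker choice here: quinolin-2-yl gives a 2.8-fold lower number from compound 2 to compound 4 (0.45 log units; beyond the scatter) and a 3.2-fold lower number from compound 1 to compound 4 (0.50 log units; beyond the scatter) against the monocyclic groups, whereas naphthalen-2-yl went the other way. Nothing available explains the step. Going by these compounds, whether pyridin-2-yl, quinolin-3-yl or an amine on the quinolin-2-yl ring would keep the lower number remains open.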